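Hydrazone series on lymphoma cells: anilino in place of amino

The compounds below may be only part of what the source reports. "The series", "measured", "known", "first", "only" and "open" are said of these compounds alone.

Compound 1 `N/N=C1\C[C@@H](c2ccc(O)cc2)Oc2cc(O)cc(O)c21` and compound 2 `Oc1ccc([C@@H]2C/C(=N\Nc3ccccc3)c3c(O)cc(O)cc3O2)cc1` share one core. In a functional assay on L5178Y cells (Mus musculus) for inhibition, read by MTT assay, with a stated time of 24 h (a higher number here means a weaker inhibitor, a lower number a stronger inhibitor), compound 1 reports only a limit, >= 11300 nM. Compound 2 in this assay likewise reports only a limit, >= 11300 nM. The change between them, (phenyl in place of hydrogen on an amine nitrogen), gives a step that the two limits leave unreadable from compound 1 to compound 2. Compound 3 `COc1ccc([C@@H]2C/C(=N\N)c3c(O)cc(OC)cc3O2)cc1` carries a second core; the difference between the two cores is not broken down here. Compound 3 in this assay also stops at a limit, >= 11300 nM. The same change, (phenyl in place of hydrogen on an amine nitrogen), leads to compound 4 `COc1ccc([C@@H]2C/C(=N\Nc3ccccc3)c3c(O)cc(OC)cc3O2)cc1`, not yet measured. For the measured compounds named here, every measured value so far sits at the limit of >= 11300 nM in this assay, at which 3 of the 3 values shown sit. The step is expected to be a step that the limit leaves unreadable from compound 3 to compound 4, since the matching one, a step that the two limits leave unreadable from compound 1 to compound 2, stays unreadable between two limits. Compound 4 is accordingly expected near 15000 nM, most probably again only a limit.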

Compound 4, half-maximal inhibitory concentration: >= 11300 nM
Compound 4 was reported as a limit (the forecaster's own chance of this, stated with the estimate: 85%); the middle value does not contradict the limit.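

Compound 3 and compound 4 both stop at a limit in this assay, so no new step can be read for amino to anilino. The compounds shown leave open how strongly any of them inhibits: the limit of >= 11300 nM in this assay, at which 4 of the 4 values shown sit.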